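A few compounds are considered here, and "the series" means these few. Any claim that something is new, unique, unknown or untested is made for them only; others in the source may bear on it.

Of the compounds shown here, three built on one shared core have been tested in an assay on IMR-32 cells for displacement of a labelled ligand from corticotropin-releasing factor receptor 1 (Homo sapiens), read by scintillation counting, with a stated time of 2 h; on this read-out lower numbers stand for stronger inhibition and higher numbers for weaker inhibition. Compound 1 `CCOc1ccc(-c2nc(OC)c(NC(CC)CC)nc2C)c(Cl)c1` gives 5.9 nM. Compound 2 `CCc1nc(-c2ccc(OC(F)F)cc2Cl)c(OC)nc1NC(CC)CC` gives 2.5 nM in this assay, and compound 3 `CCc1nc(NC(CC)CC)c(I)nc1-c1ccc(Cl)cc1Cl` gives 12 nM. Among these three numbers, compound 1 stands second highest: compound 3 lies nearest with a higher number, compound 2 furthest with a lower number, and both gaps lie beyond the usual scatter of repeated measurements.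

Compound 4 `CCC(CC)Nc1nc(C)c(-c2ccc(Cl)cc2Cl)nc1OC` has not yet been measured. It differs from compound 1 in a single place: chloro in place of ethoxy on an aromatic carbon. Going by the values given here, no pair among the measured compounds shows exactly this exchange. Compound 3 does carry two chloro groups on its aromatic ring, as compound 4 will, but it also differs from compound 1 elsewhere, so its number is only a loose hint. The expectation is a small step, if any, towards a higher number, likely within the scatter. Compound 4 is therefore estimated at 8 nM, with a plausible range from 3 nM to 20 nM. This amounts to an expected step of a 1.4-fold higher number from compound 1 to compound 4 (0.13 log units; within the scatter).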

Compound 4, inhibition constant: 4.3 nM
For compound 4 the middle estimate is 1.9-fold (0.27 log units) above the measured one, and the stated range covers the measured number.
By their numbers in this assay, from the lowest: compounds 2, 4 and 1 (each within the scatter of the next, the first and the last beyond it); then compound 3.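

In this assay, chloro in place of ethoxy on this aromatic carbon, para to a large group and meta to a chloro group, gives a 1.4-fold lower number from compound 1 to compound 4 (0.14 log units; within the scatter), so the two compounds cannot be told apart. Going by these compounds alone, this is the first direct reading at this place, and it shows that a group of three heavy atoms with one hydrogen-bond acceptor can give way to a single chlorine, with no hydrogen-bond acceptor, without a step beyond the scatter. No measurement shown here accounts for this tolerance.

On these data alone, only these two groups can be compared directly at this place, so how far the tolerance extends remains open. A longer chain such as butoxy, an amine or a carboxylic acid on this carbon could give a very different number.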